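Swapping Methoxy for Methoxycarbonyl on the Aryl Ring

The source may report more compounds than this note shows. Statements on the series, on what has been measured and on what is new or still open speak of the compounds shown alone.

Compound 1 `COC(=O)C1=C(C)N=C(C)N(CCCCCN2CCC(c3ccccc3C(F)(F)F)CC2)C1c1ccc(F)c(F)c1`: 500 nM
Compound 2 `COC(=O)C1=C(C)N=C(C)N(CCCCCN2CCC(c3ccccc3OC)CC2)C1c1ccc(F)c(F)c1`: 140 nM
Compound 3 `COC(=O)C1=C(C)N=C(C)N(CCCCCN2CCN(c3ccccc3OC)CC2)C1c1ccc(F)c(F)c1`: 67 nM

All three share one core and were tested in an assay on isolated protein for binding affinity to Alpha-1B adrenergic receptor (Homo sapiens); a higher number here means a weaker inhibitor, a lower number a stronger inhibitor. Compound 3 gives the lowest number of the three: compound 2 stands at 140 nM and compound 1 at 500 nM, and both gaps lie beyond the scatter. Compound 4 `COC(=O)C1=C(C)N=C(C)N(CCCCCN2CCN(c3ccccc3C(=O)OC)CC2)C1c1ccc(F)c(F)c1` has not yet been measured. It differs from compound 3 by methoxycarbonyl in place of methoxy on an aromatic carbon. Among the measured compounds shown here, no measured step involves a methoxycarbonyl group. For the measured compounds named here, the only measured step is a 3.6-fold lower number from compound 1 to compound 2 (0.55 log units; beyond the scatter), and it concerns a different exchange, so it bears only loosely here. A modest step is plausible, with a weaker outcome somewhat more likely than a stronger one. Compound 4 is therefore estimated at 150 nM, within 50 nM to 500 nM, meaning an expected step of a 2.2-fold higher number from compound 3 to compound 4 (0.35 log units; beyond the scatter).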

Compound 4, inhibition constant: 34 nM
For compound 4 the middle estimate is 4.4-fold (0.64 log units) above the measured one; the measured number lies below the stated range.
By their numbers in this assay, from the lowest: compounds 4 and 3 (each within the scatter of the next); then compound 2; then compound 1.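

In this assay the exchange of methoxy for methoxycarbonyl gives a 2.0-fold lower number from compound 3 to compound 4 (0.29 log units; within the scatter) and so separates the two groups by no more than repeat measurements would. On this aromatic carbon, ortho to a large group, the larger methoxycarbonyl with its added hydrogen-bond acceptor therefore reads the same as methoxy. Nothing available explains this match. On these data alone, whether a carboxylic acid or an amide on the same carbon would also read the same remains open. So does whether methoxycarbonyl would match methoxy on the core of compound 2.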